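Working notes on cytotoxicity in a four-compound series

The source may report more compounds than this note shows. Statements on the series, on what has been measured and on what is new or still open speak of the compounds shown alone.

Compound 1 `COc1ccc(C(=O)N2CCN(CC(=O)N3CCN(CCCc4c[nH]c5ccccc45)CC3)CC2)cc1` serves as the reference. In an ADME assay on HEK293 cells (Homo sapiens) for cytotoxicity, read by MTT assay, with a stated time of 72 h (on this read-out higher numbers stand for weaker inhibition and lower numbers for stronger inhibition), compound 1 gives 156000 nM. Compound 2 `O=C(CN1CCN(C(=O)c2ccc(Br)cc2)CC1)N1CCN(CCCc2c[nH]c3ccccc23)CC1` differs from it by bromo in place of methoxy on an aromatic carbon, and in this assay compound 2 gives 71900 nM; the step is a 2.2-fold lower number from compound 1 to compound 2 (0.34 log units; beyond the scatter). Compound 3 `COc1ccc(C(=O)N2CCN(CC(=O)N3CCN(CCCc4c[nH]c5ccc(OC)cc45)CC3)CC2)cc1` carries methoxy in place of hydrogen on an aromatic carbon on the core of compound 1, and in this assay compound 3 gives 190000 nM, the step being a 1.2-fold higher number from compound 1 to compound 3 (0.09 log units; within the scatter). Compound 3 has the highest of the three numbers; its gap to compound 1 is within the scatter, its gap to compound 2 beyond it.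

Compound 4 `COc1ccc2[nH]cc(CCCN3CCN(C(=O)CN4CCN(C(=O)c5ccc(Br)cc5)CC4)CC3)c2c1` is not yet measured. It is related to compound 3 by bromo in place of methoxy on an aromatic carbon, the same change as from compound 1 to compound 2; the two pairs are the only occurrences of that change among these compounds, and the place is described in the same words in both. The two cores differ by methoxy in place of hydrogen on an aromatic carbon. Going by the values given here, the one measured instance of the change reads a 2.2-fold lower number from compound 1 to compound 2 (0.34 log units; beyond the scatter).

On that basis the step from compound 3 to compound 4 in this assay is expected to be a 2.2-fold lower number from compound 3 to compound 4 (0.34 log units; beyond the scatter), a modest lowering. This expectation rests on compound 3 with 190000 nM and on the measured 2.2-fold lower number from compound 1 to compound 2 (0.34 log units; beyond the scatter). Compound 4 is estimated to give about 86000 nM in this assay. Given the scatter of this kind of measurement, the expected range for compound 4 runs from 40000 nM to 180000 nM.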

Compound 4, half-maximal inhibitory concentration: 80500 nM
Beside the measured number, compound 4's estimate is 1.1-fold (0.03 log units) above it; the range from low to high includes it.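

In this assay, replacing 4-methoxyphenyl with 4-bromophenyl gives much the same result on both cores, and the new reading is a 2.4-fold lower number from compound 3 to compound 4 (0.37 log units; beyond the scatter), which matches the earlier step on the core of compound 1: the same change on two cores in this assay, a 2.2-fold lower number (0.34 log units; beyond the scatter) from compound 1 to compound 2 and a 2.4-fold lower number (0.37 log units; beyond the scatter) from compound 3 to compound 4, 1.1-fold (0.04 log units) apart, within the scatter of two such steps. The methoxy in place of hydrogen on the core has no readable effect with either partner, the new reading being a 1.1-fold higher number from compound 2 to compound 4 (0.05 log units; within the scatter), so the four compounds behave as two independent changes: the same change on two cores in this assay, a 1.2-fold higher number (0.09 log units; within the scatter) from compound 1 to compound 3 and a 1.1-fold higher number (0.05 log units; within the scatter) from compound 2 to compound 4, 1.1-fold (0.04 log units) apart, within the scatter of two such steps. This supports carrying the bromo-for-methoxy step between these two cores in this assay only, since it rests on one pair of cores and one pair of groups, and it does not show why the number falls or that the step would transfer to a core that differs more widely.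

From the compounds shown here alone, whether the step holds with another group at that place on the six-membered aromatic ring, such as an amine or a carboxylic acid, or on a core with a longer chain leading to the indole-bearing end, remains open. Also open, going by these compounds, is whether the same agreement between the two steps would appear in another cell line or after another exposure time.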